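Swapping the sulfonyl aryl group of compound 1

This account rests on a few compounds, and the source may have more. Where it says the series, first, only, none or still open, it means among the compounds named here.

Within the data shown here, compound 1 `Cc1ccccc1C(=O)NCc1ccc(CNS(=O)(=O)c2ccccc2C)cc1` is the stronger of the two compounds measured so far in an assay on MDA-MB-231 cells for displacement of a labelled ligand from C-X-C chemokine receptor type 4 (Homo sapiens), read by fluorescence and microscopy, with stated times of 10 min and 30 min (a higher number here means that more compound is needed for the effect, a lower number that less compound is needed), where compound 1 gives 10 nM. Among the measured compounds shown here, its only measured neighbour, compound 2 `COc1ccccc1C(=O)NCc1ccc(CNS(=O)(=O)c2ccccc2C)cc1`, differs on the amide side of the shared core, and in this assay compound 2 gives 1000 nM; the step is a 100-fold higher number from compound 1 to compound 2 (2.00 log units; beyond the scatter), a large loss for a small change on one end of the molecule.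

The next compound, compound 3 `Cc1ccccc1C(=O)NCc1ccc(CNS(=O)(=O)c2ccc([N+](=O)[O-])cc2)cc1`, changes the other end of the core instead: 4-nitrophenyl in place of 2-methylphenyl on a sulfonyl sulfur. For the measured compounds named here, no measured pair touches the group on the sulfonyl sulfur, so the step from compound 1 to compound 2 does not speak directly to this change; it shows only that this core can respond strongly to a single replacement. With nothing to anchor the direction, a modest loss is assumed as the more cautious expectation, and the step expected is a 5.0-fold higher number from compound 1 to compound 3 (0.70 log units; beyond the scatter). Compound 3 is therefore estimated at 50 nM in this assay, with a range from 5 nM to 500 nM.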

Compound 3, effective concentration (reported as EC, without a stated level of effect): 100 nM
The estimate for compound 3 lay 2.0-fold (0.30 log units) below the measured number; measured number inside the range.
By their numbers in this assay, from the lowest: compound 1; then compound 3; then compound 2.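

The swap at the sulfonyl sulfur gives, in this assay, a 10-fold higher number from compound 1 to compound 3 (1.00 log units; beyond the scatter), so the group at this end of the molecule does affect the number and is not a passive part of the structure. The change here is also far larger in atoms than the one on the amide side, with 4-nitrophenyl bringing more heavy atoms and two hydrogen-bond acceptors that 2-methylphenyl lacks, yet the step is smaller than a 100-fold higher number from compound 1 to compound 2 (2.00 log units; beyond the scatter), which shows that the size of a replacement on this core does not by itself set the size of the step. Nothing measured here bears on which feature of the swap lies behind the step from compound 1 to compound 3.

The swap changes both the kind of group on the ring and where it sits, so 4-methylphenyl or 2-nitrophenyl on the sulfonyl sulfur would be needed to tell these two apart. Going by these compounds, it also remains open how a plain phenyl, a 4-aminophenyl or a short alkyl chain would behave at this position, and whether any group here could give a lower number than 2-methylphenyl does.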